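Replacing the 4-chlorophenyl group of compound 1

The compounds below may be only part of what the source reports. "The series", "measured", "known", "first", "only" and "open" are said of these compounds alone.

In a physicochemical assay for solubility, measured as kinetic solubility (on this read-out higher numbers stand for higher solubility and lower numbers for lower solubility), compound 1 (`CNC(=O)c1cc(C(=O)N[C@H]2CC[C@H](O)CC2)n([C@@H](C)c2ccc(Cl)cc2)n1`) reads >= 132 ug/mL as a limit of the assay, so it has no exact place on the scale. Compound 2 (`CNC(=O)c1cc(C(=O)N[C@H]2CC[C@H](O)CC2)c([C@@H](C)c2cccc(F)c2)o1`) also reads >= 63 ug/mL as a limit. Within the data shown here, compound 3 (`CCC(=O)c1c[nH]c(C(=O)NC)c1`) gives 87 ug/mL as the only true number of the three. In compound 4 (`CNC(=O)c1cc(C(=O)N[C@H]2CC[C@H](O)CC2)n([C@@H](C)c2cccc(C(F)(F)F)c2)n1`) 3-(trifluoromethyl)phenyl stands in place of 4-chlorophenyl on a saturated chain carbon bound to an aromatic nitrogen and a saturated chain carbon (3-(trifluoromethyl)phenyl in place of 4-chlorophenyl on a saturated chain carbon bound to an aromatic nitrogen and a saturated chain carbon). Among the measured compounds shown here, no measured pair shows this change, so a modest fall in this assay is only an expectation. The estimated step is an at least 1.4-fold lower number from compound 1 to compound 4 (0.16 log units; that floor lies within the scatter) and may not clear the usual scatter. Compound 4 is expected at 90 ug/mL (35 ug/mL to 200 ug/mL) by this estimate.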

Compound 4, solubility: 7 ug/mL
Compound 4: the middle estimate sits 13-fold (1.11 log units) above what was measured; measured number outside the range, below it.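

In this assay, replacing 4-chlorophenyl with 3-(trifluoromethyl)phenyl gives an at least 18-fold lower number from compound 1 to compound 4 (1.27 log units; beyond the scatter). Compound 1 reads >= 132 ug/mL, which is a limit. Among these compounds, no earlier pair differed in one place, so only now is it clear that the group on this saturated chain carbon bound to an aromatic nitrogen and a saturated chain carbon can move the reading well beyond the scatter.

The compounds shown do not separate the effect of trifluoromethyl from that of its 3-placement on the phenyl. As far as these compounds go, how a phenyl carrying an amine would read also remains open.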